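A Chloro-to-Methoxy Exchange and Its Expected Cost

The source may hold more compounds than are shown below. What is called first, only, known or untested is meant among the compounds shown, and "the series" means these compounds.

Of the compounds shown here, two have been measured in a functional assay on HEK293 cells for agonist activity at D(4) dopamine receptor (Homo sapiens), read by FLIPR; on this read-out lower numbers stand for an effect already at smaller amounts and higher numbers for an effect only at larger amounts of compound. Compound 1 `COc1cccc(C)c1NC(=O)CN1CCC(c2cccc[n+]2[O-])CC1` gives 340 nM in this assay. Compound 2 `Cc1cccc(Cl)c1NC(=O)CN1CCC(c2ccccn2)CC1` gives 60 nM, the lowest of the two numbers; its nearest neighbour is compound 1, whose number is higher by a margin beyond the usual scatter. The unmeasured compound 3 `COc1cccc(C)c1NC(=O)CN1CCC(c2ccccn2)CC1` is derived from compound 2 by a single change: methoxy in place of chloro on an aromatic carbon. No directly measured pair with this exact exchange exists here, so the size of the step cannot be read off any shown data. The expectation rests only on where compound 2 stands and on the fact that the other measured compound, compound 1, sits at the higher of the two numbers. The step of a 2.5-fold higher number from compound 2 to compound 3 (0.40 log units; beyond the scatter) is therefore estimated as a moderate loss rather than a drastic one, in the direction of a higher number. Compound 3 is expected to give about 150 nM in this assay, with a range from 50 nM to 450 nM.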

Compound 3, half-maximal effective concentration: 40 nM
Beside the measured number, compound 3's estimate is 3.8-fold (0.57 log units) above it; the whole stated range lies above it.
By their numbers in this assay, from the lowest: compounds 3 and 2 (each within the scatter of the next); then compound 1.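

In this assay the exchange of chloro for methoxy, on an aromatic carbon ortho to a large group, gives a 1.5-fold lower number from compound 2 to compound 3 (0.18 log units; within the scatter), so the two groups cannot be told apart at this position on this read-out. The extra heavy atom and the hydrogen-bond acceptor that enter with methoxy thus leave the number within the scatter, though this rests on a single pair on a single core. Among the compounds shown here, compound 3 also provides the first comparison in one place on a saturated ring carbon, where a group of 6 heavy atoms in place of a group of 7 gives an 8.5-fold lower number from compound 1 to compound 3 (0.93 log units; beyond the scatter), so in this small set that exchange, unlike the one on the aromatic carbon, is a step beyond the scatter.

No measurement shown bears on the reason for either step. From the compounds shown here alone, it remains open whether other groups at the same aromatic position, such as fluoro, ethoxy or an amine, would also stay within the scatter, and whether the equivalence of chloro and methoxy would hold on a core carrying the group of 7 heavy atoms.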